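The source may report more compounds than this note shows. Statements on the series, on what has been measured and on what is new or still open speak of the compounds shown alone.

Measured so far in a functional assay, with a stated time of 10 min; on this read-out lower numbers stand for stronger inhibition and higher numbers for weaker inhibition:
- compound 1 `COc1cc(O)c(C(C)=O)cc1Br`: 3000000 nM
- compound 2 `CCOc1cc(OC)c(Br)cc1C(C)=O`: 57700000 nM

Compound 2 carries the higher number of the two. Among the compounds with values here, the only measured step is a 19-fold higher number from compound 1 to compound 2 (1.28 log units; beyond the scatter), with ethyl in place of hydrogen on an oxygen on an aromatic ring.

Compound 3 `CCCCOc1cc(OC)c(Br)cc1C(C)=O` differs from compound 2 by ethyl in place of hydrogen on a saturated chain carbon, two bonds along the chain from an oxygen on an aromatic ring, so ethoxy becomes butoxy. The measured step bears on this change only in part, since it placed ethyl on the oxygen, whereas here the existing chain grows longer. Within the data shown here, with only that step to go on, a change in the same direction but smaller in size is expected in this assay. The estimate for this change is a 2.1-fold higher number from compound 2 to compound 3 (0.32 log units; beyond the scatter). For compound 3 the expected value is 120000000 nM, within an estimated range of 25000000 nM to 500000000 nM.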

Compound 3, half-maximal inhibitory concentration: 56900000 nM
Compound 3: the middle estimate sits 2.1-fold (0.32 log units) above what was measured; the measured number falls inside the stated range.
By their numbers in this assay, from the lowest: compound 1; then compounds 3 and 2 (each within the scatter of the next).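

In this assay, the ethyl added on a saturated chain carbon, two bonds along the chain from an oxygen on an aromatic ring, gives a 1.0-fold lower number from compound 2 to compound 3 (0.01 log units; within the scatter), so going from ethoxy to butoxy leaves the number within the scatter. Butyl in place of hydrogen on that oxygen gives a 19-fold higher number from compound 1 to compound 3 (1.28 log units; beyond the scatter), a step of the same printed size as a 19-fold higher number from compound 1 to compound 2 (1.28 log units; beyond the scatter). Across these three compounds, the large step therefore goes with replacing the hydrogen on the oxygen, and extending the chain from ethyl to butyl adds nothing beyond the scatter.

As far as these compounds go, whether a methyl on this oxygen, a longer chain, or a chain carrying an amine or a carboxylic acid would depart from these numbers remains open. No measurement at hand gives a reason for either the large step or the flat one.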